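The source may hold more compounds than are shown below. What is called first, only, known or untested is meant among the compounds shown, and "the series" means these compounds.

Measured compounds:
- compound 1 `O=C(c1ccc(Cl)cc1)N1CCN(c2nc(=O)c3cc(C(F)(F)F)cc([N+](=O)[O-])c3s2)CC1`: 5.19 ug/mL
- compound 2 `CC(=O)N1CCN(c2nc(=O)c3cc(C(F)(F)F)cc([N+](=O)[O-])c3s2)CC1`: 83.9 ug/mL
- compound 3 `CCC(C)C(=O)N1CCN(c2nc(=O)c3cc(C(F)(F)F)cc([N+](=O)[O-])c3s2)CC1`: 104 ug/mL

In a physicochemical assay for solubility, read by HPLC (a higher number here means a more soluble compound, a lower number a less soluble compound), compound 3 gives the highest of the three numbers. Its nearest neighbour is compound 2, and the step of a 1.2-fold higher number from compound 2 to compound 3 (0.09 log units; within the scatter) lies within the scatter, so the two cannot be ordered. Compound 1 sits furthest away, and the step of a 20-fold higher number from compound 1 to compound 3 (1.30 log units; beyond the scatter) is large, as is a 16-fold higher number from compound 1 to compound 2 (1.21 log units; beyond the scatter).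

Compound 4 `O=C(C1CCCC1)N1CCN(c2nc(=O)c3cc(C(F)(F)F)cc([N+](=O)[O-])c3s2)CC1` differs from compound 3 by cyclopentyl in place of sec-butyl on a carbonyl carbon. Within the data shown here, the only measured step that bears on it is the alkyl-to-alkyl change a 1.2-fold higher number from compound 2 to compound 3 (0.09 log units; within the scatter), which stayed within the scatter. The large steps from compound 1 concern a 4-chlorophenyl leaving a carbonyl carbon and therefore say little about swapping one alkyl group for another. In this assay compound 4 is thus expected to stay close to compound 3, with a step of a 1.3-fold lower number from compound 3 to compound 4 (0.11 log units; within the scatter) that should not exceed the scatter. The estimate for compound 4 is 80 ug/mL, with a range from 35 ug/mL to 180 ug/mL.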

Compound 4, solubility: 5.34 ug/mL
Compound 4: the middle estimate sits 15-fold (1.18 log units) above what was measured, and the stated range ends above it.
By their numbers in this assay, from the lowest: compounds 1 and 4 (each within the scatter of the next); then compounds 2 and 3 (each within the scatter of the next).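

In this assay, the new result shows that exchanging one alkyl group for another on this carbonyl carbon can produce a large step: cyclopentyl in place of sec-butyl gives a 19-fold lower number from compound 3 to compound 4 (1.29 log units; beyond the scatter), and cyclopentyl in place of methyl gives a 16-fold lower number from compound 2 to compound 4 (1.20 log units; beyond the scatter), although sec-butyl in place of methyl stayed within the scatter. Compound 4 also cannot be separated from compound 1, with a 1.0-fold higher number from compound 1 to compound 4 (0.01 log units; within the scatter), so among these four compounds the two groups with a ring, cyclopentyl and 4-chlorophenyl, stand at the low end and the two without one at the high end. Nothing measured here accounts for this split.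

The compounds shown leave open whether the ring itself matters or the size of the group. An open n-pentyl chain, a smaller cyclopropyl ring or a tetrahydropyranyl ring at this position could help separate the two.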